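Second methyl on the 4-methylphenyl group

A few compounds are considered here, and "the series" means these few. Any claim that something is new, unique, unknown or untested is made for them only; others in the source may bear on it.

Measured so far:
compound 1 `O=C(Nc1ccc(Oc2ccnc3[nH]ccc23)c(F)c1)c1cc(-c2ccccc2)ccn1`, 4950 nM
compound 2 `Cc1ccc(-c2ccnc(C(=O)Nc3ccc(Oc4ccnc5[nH]ccc45)c(F)c3)c2)cc1`, 3120 nM

Both were run in a functional assay on A549 cells (Homo sapiens) for cytotoxicity, read by MTT assay, with a stated time of 72 h; a higher number here means a weaker inhibitor, a lower number a stronger inhibitor. Compound 1 gives 4950 nM and compound 2 gives 3120 nM. Compound 2 and compound 1 lie within the scatter of each other, as the step of a 1.6-fold lower number from compound 1 to compound 2 (0.20 log units; within the scatter) shows; no order between them can be claimed on these two numbers.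

Compound 3 `Cc1ccc(-c2ccnc(C(=O)Nc3ccc(Oc4ccnc5[nH]ccc45)c(F)c3)c2)c(C)c1` is not yet measured. It differs from compound 2 by methyl in place of hydrogen on an aromatic carbon. Among the compounds with values here, the only measured step that bears on this change is a 1.6-fold lower number from compound 1 to compound 2 (0.20 log units; within the scatter), likewise a methyl in place of hydrogen on an aromatic carbon of the same ring, and that step stayed within the scatter. Within the data shown here, a second methyl on that ring has no measured counterpart. On this basis the expected step from compound 2 to compound 3 is a 1.2-fold lower number from compound 2 to compound 3 (0.06 log units; within the scatter), that is, no shift beyond the scatter in this assay. Compound 3 is therefore estimated at 2700 nM, with a range from 1100 nM to 7000 nM. The range is kept wide; a single measured step informs it.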

Compound 3, half-maximal inhibitory concentration: 4350 nM
The estimate for compound 3 lay 1.6-fold (0.21 log units) below the measured number, within the range that was stated.
By their numbers in this assay, from the lowest: compounds 2, 3 and 1 (each within the scatter of the next).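

In this assay, the methyl added on the aromatic carbon ortho to a large group and meta to a methyl group, which turns 4-methylphenyl into 2,4-dimethylphenyl, gives a 1.4-fold higher number from compound 2 to compound 3 (0.14 log units; within the scatter), so this position takes a methyl with no shift that can be told from the scatter. Taken as a whole, the change from phenyl to 2,4-dimethylphenyl gives a 1.1-fold lower number from compound 1 to compound 3 (0.06 log units; within the scatter), so neither one methyl nor two on this ring separates from the plain phenyl in this read-out, and the three compounds form a single cluster of values. No measurement at hand bears on why the numbers stay together.

The compounds shown carry only hydrogen or methyl on this ring, so it remains open whether a different group on the same carbon, such as methoxy, an amine or a carboxylic acid, would move the number beyond the scatter. As far as these compounds go, it also remains open whether any change on the shared core would give a step that can be read in this assay.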